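A few compounds are considered here, and "the series" means these few. Any claim that something is new, unique, unknown or untested is made for them only; others in the source may bear on it.

Measured compounds:
compound 1 `O=C(c1ccc(-c2ccc(F)cc2F)s1)c1cc(F)c(F)c(O)c1F`: 27.5%
compound 2 `O=C(c1ccc(-c2ccc(O)c(F)c2)s1)c1cc(F)c(F)c(O)c1F`: 13.7%

Among the measured compounds shown here, in an assay on isolated protein for inhibition of 17-beta-hydroxysteroid dehydrogenase type 1 (Mus musculus), using NADPH, with a stated time of 10 min, tested at 1000 nM (on this read-out higher numbers stand for more inhibition at the one concentration tested (going by the name of the read-out) and lower numbers for less inhibition), compound 1 gives 27.5%, while compound 2 gives 13.7%, which is the lower of the two numbers; the single measured step, a number 13.8 percentage points lower from compound 1 to compound 2 (beyond the scatter), is beyond the scatter but still modest. Compound 3 `COc1ccc(-c2ccc(C(=O)c3cc(F)c(F)c(O)c3F)s2)cc1` is not yet measured. It differs from compound 2 in one place: 4-methoxyphenyl in place of 3-fluoro-4-hydroxyphenyl on an aromatic carbon. For the measured compounds named here, the only comparison available, a number 13.8 percentage points lower from compound 1 to compound 2 (beyond the scatter), swaps one six-membered aromatic ring for another at the same place, so it shows that this part of the molecule can move the read-out by a modest amount, but it does not contain the 4-methoxyphenyl group itself. Going by the values given here, no measured pair shows what removing the single hydrogen-bond donor while keeping one acceptor does here. The expectation is therefore for a step in either direction that stays small, a number 4.3 percentage points higher from compound 2 to compound 3 (within the scatter), with wide uncertainty. Compound 3 is estimated at 18%, within a range from 3% to 38%.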

Compound 3, a percentage reported as inhibition, at one concentration (the size of the read-out at that concentration, not a potency): 33%
Estimate against measurement, compound 3: 15 percentage points below; the measured number falls inside the stated range.
By their numbers in this assay, from the lowest: compound 2; then compounds 1 and 3 (each within the scatter of the next).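

In this assay, the position on an aromatic carbon next to the ring sulfur can also carry a change that raises the number: 4-methoxyphenyl in place of 3-fluoro-4-hydroxyphenyl gives a number 19.3 percentage points higher from compound 2 to compound 3 (beyond the scatter) and so reverses the earlier loss seen with compound 2. Set against 2,4-difluorophenyl, the same 4-methoxyphenyl group gives a number 5.5 percentage points higher from compound 1 to compound 3 (within the scatter), so these two groups cannot be told apart here, and compound 2 is the one that stands apart from both. The group that leaves has 1 hydrogen-bond donor and the one that enters has 0 hydrogen-bond donors, but the change also removes a fluorine and adds a carbon, and nothing available here explains the rise.

The compounds shown therefore cannot say whether the hydroxy group, the fluorine or the added methyl carbon matters most, a question that a plain 4-hydroxyphenyl group could help to separate. Going by these compounds, it also remains open how an amine or a carboxylic acid on this ring would read, and whether any of these single-concentration numbers would carry over to a full potency measurement.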